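Anilide removal in a trimethoxybenzophenone series

This account rests on a few compounds, and the source may have more. Where it says the series, first, only, none or still open, it means among the compounds named here.

Measured so far:
- compound 1 `COc1ccc(C(=O)c2cc(OC)c(OC)c(OC)c2)cc1N`: 80 nM
- compound 2 `COc1ccc(C(=O)c2cc(OC)c(OC)c(OC)c2)cc1NC(=O)/C=C/c1ccc(F)cc1`: 300 nM
- compound 3 `COc1cc(C(=O)c2cc(OC)c(OC)c(OC)c2)cc(NC(=O)/C=C/c2ccc(F)cc2)c1OC`: 1000 nM

In a functional assay on ME-180 cells (Homo sapiens) for cytotoxicity, read by MTT assay, with a stated time of 72 h (on this read-out lower numbers stand for stronger inhibition and higher numbers for weaker inhibition), compound 1 gives 80 nM, compound 2 gives 300 nM and compound 3 gives 1000 nM. One step is already measured: a 3.8-fold lower number from compound 2 to compound 1 (0.57 log units; beyond the scatter), the change being (hydrogen in place of (2-(4-fluorophenyl)ethenyl)carbonyl on a nitrogen on an aromatic ring). The two cores differ by methoxy in place of hydrogen on an aromatic carbon, and that step reads a 3.3-fold higher number from compound 2 to compound 3 (0.52 log units; beyond the scatter), so compound 3 stands at the highest number of the three.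

Compound 4 `COc1cc(C(=O)c2cc(OC)c(OC)c(OC)c2)cc(N)c1OC` is not yet measured. It arises from compound 3 by hydrogen in place of (2-(4-fluorophenyl)ethenyl)carbonyl on a nitrogen on an aromatic ring. The place is the same word for word as in the measured pair, so this is the same change made on the second core. The expectation is therefore a step of about the size already seen, a 3.7-fold lower number from compound 3 to compound 4 (0.57 log units; beyond the scatter), resting on the measured 3.8-fold lower number from compound 2 to compound 1 (0.57 log units; beyond the scatter) from compound 2 to compound 1. Whether the second core carries the change equally is not shown by anything here, and the range is set wide for that reason.

Compound 4 is estimated at 270 nM in this assay, expected between 100 nM and 700 nM.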

Compound 4, half-maximal inhibitory concentration: 12200 nM
Compound 4: middle estimate off by 45-fold (1.65 log units), on the low side, outside the stated range (above it).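

In this assay, hydrogen in place of (2-(4-fluorophenyl)ethenyl)carbonyl on the nitrogen gives a 12-fold higher number from compound 3 to compound 4 (1.09 log units; beyond the scatter), so the change reverses direction between the two cores: the same change on two cores in this assay, a 3.8-fold lower number (0.57 log units; beyond the scatter) from compound 2 to compound 1 and a 12-fold higher number (1.09 log units; beyond the scatter) from compound 3 to compound 4, 46-fold (1.66 log units) apart, beyond the scatter of two such steps

Read the other way, methoxy in place of hydrogen on an aromatic carbon gives a 150-fold higher number from compound 1 to compound 4 (2.18 log units; beyond the scatter) when the nitrogen carries only hydrogen, a much larger step than with the acylated nitrogen: the same change on two cores in this assay, a 3.3-fold higher number (0.52 log units; beyond the scatter) from compound 2 to compound 3 and a 150-fold higher number (2.18 log units; beyond the scatter) from compound 1 to compound 4, 46-fold (1.66 log units) apart, beyond the scatter of two such steps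

The two changes therefore do not act independently across these four compounds, and a step measured on one core cannot be carried to the other here, but the data do not show why the steps differ or whether the same holds for any other pair of cores.

Open, on these data alone, is whether the drop at compound 4 belongs to the bare amino group or would also appear with a small group on that nitrogen, such as acetyl or methyl. Also open, as far as these compounds go, is whether a hydroxy group in place of the added methoxy would give a similar dependence on the nitrogen substituent.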